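Trimming the side chain of compound 3

This account rests on a few compounds, and the source may have more. Where it says the series, first, only, none or still open, it means among the compounds named here.

In a physicochemical assay for metabolic stability, in simulated intestinal fluid, with a stated time of 15 min, tested at 4 uM (a lower number here means that less of the compound is left, a higher number that more of the compound is left), compound 3 `COC[C@H](NC(=O)c1cc(C)on1)C(=O)N[C@@H](CC(C)C)C(=O)N[C@@H](CC(C)C)C(=O)[C@@]1(C)CO1` gives 90%. Compound 2 `CC[C@H](NC(=O)[C@H](COC)NC(=O)c1cc(C)on1)C(=O)N[C@@H](CC(C)C)C(=O)[C@@]1(C)CO1` gives 100%, within the scatter of compound 3. Going by the values given here, compound 1 `COC[C@H](NC(=O)c1cc(OC)no1)C(=O)N[C@@H](COC)C(=O)N[C@@H](CC(C)C)C(=O)[C@@]1(C)CO1` gives 35%, well beyond the scatter of compound 3, but no measured step links compound 1 to the others. Compound 4 `COC[C@H](NC(=O)c1cc(C)on1)C(=O)N[C@@H](C)C(=O)N[C@@H](CC(C)C)C(=O)[C@@]1(C)CO1` has hydrogen in place of isopropyl on a saturated chain carbon, two bonds along the chain from an amide-type nitrogen and a carbonyl carbon. Among the compounds with values here, the one measured step at this place, isopropyl in place of methyl, is a number 10 percentage points lower from compound 2 to compound 3 (within the scatter), so no step beyond the scatter is expected in this assay. The expected step is a number 2 percentage points lower from compound 3 to compound 4 (within the scatter). The estimate for compound 4 is 88%, with an expected range from 65% to 100%.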

Compound 4, percent of the compound remaining: 100%
Compound 4: middle estimate off by 12 percentage points, on the low side, and the stated range covers the measured number.
By their numbers in this assay, from the lowest: compound 1; then compounds 3, 2 and 4 (each within the scatter of the next).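

At the saturated chain carbon, this assay gives a number 10 percentage points higher from compound 3 to compound 4 (within the scatter) for hydrogen in place of isopropyl, and no change at the digits printed from compound 2 to compound 4 (within the scatter) for hydrogen in place of methyl. The earlier compounds held only one step at this place; now all three pairs lie within the scatter, so the smallest side chain shown reads the same as the two larger ones. No measurement shown offers an explanation for this. Going by these compounds, how this place would respond to an amine or a carboxylic acid stays open. Going by these compounds alone, also open is what separates compound 1, at 35%, since no step links it to the others.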